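This account rests on a few compounds, and the source may have more. Where it says the series, first, only, none or still open, it means among the compounds named here.

Measured compounds:
compound 1 `ClCc1ccccc1Cn1cnc2c(Cl)ncnc21` — 3020 nM
compound 2 `ClCc1ccc(Cn2cnc3nc(Cl)nc(Cl)c32)cc1` — 17800 nM

In a functional assay on PC-3 cells (Homo sapiens) for cytotoxicity, read by sulforhodamine B assay, with a stated time of 48 h (on this read-out lower numbers stand for stronger inhibition of growth and higher numbers for weaker inhibition of growth), compound 1 gives 3020 nM and compound 2 gives 17800 nM, so compound 2 stands at the higher of the two numbers, with the gap to compound 1 beyond the scatter. Among the compounds with values here, the two differ in more than one place, so no single step is drawn between them.

Compound 3 `ClCc1ccc(Cn2cnc3ncnc(Cl)c32)cc1` follows from compound 2 by the change (hydrogen in place of chloro on an aromatic carbon), a hydrogen in place of chloro on an aromatic carbon between two ring nitrogen atoms. Compound 3 keeps the single-chloro core of compound 1 with the benzyl pattern of compound 2. Within the data shown here, with no measured step for this change, the expectation rests on compound 1 with 3020 nM: a modest move toward a lower number is expected, a 2.2-fold lower number from compound 2 to compound 3 (0.35 log units; beyond the scatter), though one possibly within the scatter. Compound 3 is estimated at 8000 nM, in the range 2500 nM to 25000 nM.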

Compound 3, concentration for 50% growth inhibition: 1580 nM
For compound 3 the middle estimate is 5.1-fold (0.70 log units) above the measured one; measured number below the stated range.
By their numbers in this assay, from the lowest: compounds 3 and 1 (each within the scatter of the next); then compound 2.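

In this assay, within the data shown here, hydrogen in place of chloro on the aromatic carbon between two ring nitrogen atoms gives an 11-fold lower number from compound 2 to compound 3 (1.05 log units; beyond the scatter), the first step that changes a single place. This position therefore matters for growth inhibition, and of the two groups shown there, hydrogen goes with the lower number. Among these compounds, still open is how an amine, a methoxy group or a methyl group would fare at this position, and the remaining chloro group has no step of its own. No available data bear on the reason for this step.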